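Adding a methoxy group to the aryl ring of compound 2

The source may report more compounds than this note shows. Statements on the series, on what has been measured and on what is new or still open speak of the compounds shown alone.

Compound 1, `COc1cc(-c2nc3cc(/C=C4\SC(=O)N(CC(=O)N5CCOCC5)C4=O)ccc3[nH]2)cc(OC)c1OC`: 1680 nM in a functional assay on HT-1080 cells (Homo sapiens) for inhibition, read by MTT assay, with a stated time of 48 h; a higher number here means a weaker inhibitor, a lower number a stronger inhibitor
Compound 2, `COc1ccc(-c2nc3cc(/C=C4\SC(=O)N(CC(=O)N5CCOCC5)C4=O)ccc3[nH]2)cc1OC`: 3320 nM in this assay

Of the compounds shown here, two sharing the same core have been measured. In this assay compound 2 gives the highest of the two numbers; its nearest neighbour is compound 1, and the step of a 2.0-fold higher number from compound 1 to compound 2 (0.30 log units; within the scatter) lies within the scatter, so the two cannot be ordered.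

Compound 3, `COc1cc(OC)c(-c2nc3cc(/C=C4\SC(=O)N(CC(=O)N5CCOCC5)C4=O)ccc3[nH]2)cc1OC`, is not yet measured. It differs from compound 2 by methoxy in place of hydrogen on an aromatic carbon. Going by the values given here, the only measured step that bears on this change is the removal of a methoxy group going from compound 1 to compound 2, which is a 2.0-fold higher number from compound 1 to compound 2 (0.30 log units; within the scatter) and within the scatter. Among the compounds with values here, that step concerns a different ring position, and no measured pair shows the exact change here, so the expectation rests on the observation that one methoxy group more or less on this ring has not moved the number beyond the scatter.

Compound 3 is therefore expected to show a step of a 1.3-fold lower number from compound 2 to compound 3 (0.12 log units; within the scatter), essentially none beyond the scatter, with an estimated value of 2500 nM, ranging from 900 nM to 8000 nM.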

Compound 3, half-maximal inhibitory concentration: 1120 nM
Compound 3: middle estimate off by 2.2-fold (0.35 log units), on the high side, and the stated range covers the measured number.
By their numbers in this assay, from the lowest: compounds 3, 1 and 2 (each within the scatter of the next, the first and the last beyond it).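

In this assay, adding a methoxy group ortho to a large group, which turns 3,4-dimethoxyphenyl into 2,4,5-trimethoxyphenyl, gives a 3.0-fold lower number from compound 2 to compound 3 (0.47 log units; beyond the scatter). Going by these compounds alone, this is the only step among the three compounds that lies beyond the scatter, so it shows that one added methoxy group on this ring can shift the number measurably, though the size of the step is modest. The two trimethoxyphenyl arrangements, by contrast, cannot be told apart, with a 1.5-fold lower number from compound 1 to compound 3 (0.18 log units; within the scatter), so these data give no ordering between them. No measurement is available here that explains the difference seen at this position.

The compounds shown leave open whether the step belongs to methoxy itself or would also appear with a hydroxyl group, a fluorine atom or a longer ethoxy chain on the same carbon. They also leave open whether a single methoxy group ortho to a large group, with no other substituent on the ring, would be enough to produce such a step.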